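The compounds below may be only part of what the source reports. "The series", "measured", "known", "first", "only" and "open" are said of these compounds alone.

Measured compounds:
- compound 1 `Cc1ccc(-c2c(S(=O)(=O)c3ccccc3)cnc3cc(C)nn23)cc1`: in a functional assay on the whole organism for inhibition, with Mus musculus as the target, with a stated time of 2 h, at a dose of 50 mg/kg by the oral route (on this read-out higher numbers stand for more inhibition at the one dose given (going by the name of the read-out) and lower numbers for less inhibition), compound 1 gives 25.2%
- compound 2 `Cc1ccc(-c2c(S(=O)(=O)c3ccccc3)cnc3cc(-c4ccccc4)nn23)cc1`: in this assay compound 2 gives 41%
- compound 3 `Cc1ccc(-c2c(S(=O)(=O)c3ccccc3)cnc3cc(-c4ccc(Br)cc4)nn23)cc1`: not yet measured in this assay

Compound 2 holds the higher of the two measured numbers; its nearest neighbour is compound 1, and the step of a number 15.8 percentage points higher from compound 1 to compound 2 (beyond the scatter) is beyond the scatter. The change that follows, from compound 2 to compound 3, is bromo in place of hydrogen on an aromatic carbon. The substituent enters on an aromatic carbon of a six-membered aromatic ring of carbon only, so the difference, cut one bond further out, reads phenyl to 4-bromophenyl.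

Among the compounds with values here, no measured step bears directly on this change. Within the data shown here, the one step in hand, a number 15.8 percentage points higher from compound 1 to compound 2 (beyond the scatter), concerns the exchange of methyl for phenyl at the same position of the shared core, not a substituent on that phenyl. Among the measured compounds shown here, with no measured precedent for a bromo at this place, no step beyond the scatter is expected in either direction, and the estimated step is a number 4 percentage points higher from compound 2 to compound 3 (within the scatter). Compound 3 is therefore estimated at 45%, with a range from 25% to 65%.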

Compound 3, a percentage reported as inhibition, in the whole organism at one dose (the size of the read-out at that dose, not a potency): 72.6%
Compound 3: the middle estimate sits 27.6 percentage points below what was measured, outside the stated range (above it).
By their numbers in this assay, from the lowest: compound 1; then compound 2; then compound 3.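

The outer phenyl ring at this position of the shared core is not a silent place in this assay: a single bromo, para to a large group, brings a number 31.6 percentage points higher from compound 2 to compound 3 (beyond the scatter), a large step, where the exchange of methyl for phenyl gave only the modest a number 15.8 percentage points higher from compound 1 to compound 2 (beyond the scatter). Taken as one exchange, 4-bromophenyl in place of methyl brings a number 47.4 percentage points higher from compound 1 to compound 3 (beyond the scatter), so the earlier pair showed only part of what this position can give, and across these three compounds the number rises from methyl through phenyl to 4-bromophenyl, with none going against that order. No measurement at hand accounts for the gain brought by the bromo.

Going by these compounds, whether the gain belongs to bromine itself or would come with any substituent at that place stays open, as chloro, methoxy, an amine or a carboxylic acid on the same phenyl would show. With one oral dose and one time point, these numbers also leave open how the compounds would rank at other doses.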